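Swapping Phenyl for Cyclohexyl on a Urea Nitrogen

The source may hold more compounds than are shown below. What is called first, only, known or untested is meant among the compounds shown, and "the series" means these compounds.

Measured compounds:
Compound 1, `COc1cc(CN(C(=O)Nc2ccc(C#N)cc2)n2cnnc2)cc(OC)c1OC`: 20600 nM
Compound 2, `COc1ccc(CN(C(=O)Nc2ccc(Cl)c(C(F)(F)F)c2)n2cnnc2)cc1OC`: > 50000 nM
Compound 3, `O=C(Nc1ccccc1)N(Cc1ccccn1)n1cnnc1`: 20200 nM

All three compounds share a core carrying a urea unit and were tested in a functional assay on DU-145 cells (Homo sapiens) for cytotoxicity, read by MTT assay, with a stated time of 48 h; on this read-out lower numbers stand for stronger inhibition and higher numbers for weaker inhibition. In this assay compound 1 gives 20600 nM and compound 3 gives 20200 nM. For compound 2 the assay reports no number but only a limit, > 50000 nM, which is the limit of > 50000 nM in this assay, at which 1 of the 3 values shown sits.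

Of the two compounds that gave numbers, compound 3 has the lower one, but its distance from compound 1 is within the usual scatter of repeated measurements, so the two cannot be told apart on these data. Both sit at weak inhibition.

Compound 4, `O=C(NC1CCCCC1)N(Cc1ccccn1)n1cnnc1`, has not yet been measured. It differs from compound 3 in a single place: cyclohexyl in place of phenyl on an amide-type nitrogen. Among the measured compounds shown here, no measured pair shows this particular exchange, so there is no step to lean on. With both numbered compounds already weak and one compound at the limit, the step of a 1.2-fold higher number from compound 3 to compound 4 (0.09 log units; within the scatter) is expected to be small, with no clear direction beyond the scatter. Compound 4 is therefore estimated at 25000 nM, within a range from 8000 nM to 80000 nM.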

Compound 4, half-maximal inhibitory concentration: > 50000 nM
Compound 4 ended at the assay's limit (the forecaster's own chance of this, stated with the estimate: 35%); middle value at least 2.0-fold (0.30 log units) away from the limit.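

Among the compounds shown here, the exchange of phenyl for cyclohexyl on an amide-type nitrogen is the first single change here that can be read, and in this assay it gives an at least 2.4-fold higher number from compound 3 to compound 4 (0.39 log units; beyond the scatter). The two groups have the same count of heavy atoms, and neither has a hydrogen-bond donor or acceptor, yet they are not interchangeable at this position: the aromatic ring of compound 3 gives a measurable number, while the non-aromatic ring of compound 4 reaches the limit. As far as these compounds go, compound 4 has only a limit rather than a number, so the step gives the smallest possible size of the change, and its full size stays unknown: the limit of > 50000 nM in this assay, at which 2 of the 4 values shown sit.

This single pair cannot show whether the same exchange would give a similar step on the other compounds, which carry different groups in more than one place. Also open, from the compounds shown here alone, is how this nitrogen would respond to a phenyl ring carrying an amine or a carboxylic acid, or to a cyclohexyl ring with a longer chain between it and the nitrogen.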